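A few compounds are considered here, and "the series" means these few. Any claim that something is new, unique, unknown or untested is made for them only; others in the source may bear on it.

Values in an assay on isolated protein for antagonist activity at Voltage-dependent L-type calcium channel subunit alpha-1C (Cavia porcellus), with a stated time of 15 min (a higher number here means a weaker inhibitor, a lower number a stronger inhibitor), for the measured members of the series:

compound 1 `COC(=O)C1=C(C)NC(C)=C(C(=O)OC2CCCCC2)C1c1csc(-c2ccc(Cl)cc2)n1`: 71900 nM
compound 2 `CCOC(=O)C1=C(C)NC(C)=C(C(=O)OC2CCCCC2)C1c1csc(-c2ccc(Cl)cc2)n1`: 100000 nM
compound 3 `COC(=O)C1=C(C)NC(C)=C(C(=O)OCc2ccccc2)C1c1csc(-c2ccc(Cl)cc2)n1`: 64900 nM

All three sit at the weak end of this assay and lie within the usual scatter of one another, so no order among them is claimed. The change from compound 1 to compound 2 is methyl in place of hydrogen on a saturated chain carbon bound to an oxygen next to a carbonyl group; the step it made is a 1.4-fold higher number from compound 1 to compound 2 (0.14 log units; within the scatter). The cores of compound 1 and compound 3 differ by benzyl in place of cyclohexyl on an oxygen next to a carbonyl group, with a step of a 1.1-fold lower number from compound 1 to compound 3 (0.04 log units; within the scatter).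

Compound 4 `CCOC(=O)C1=C(C)NC(C)=C(C(=O)OCc2ccccc2)C1c1csc(-c2ccc(Cl)cc2)n1` is not yet measured. Among the measured compounds shown here, it differs from compound 3 by methyl in place of hydrogen on a saturated chain carbon bound to an oxygen next to a carbonyl group, the same change as the one from compound 1 to compound 2, at a place described in the same words. The expected step is a 1.3-fold higher number from compound 3 to compound 4 (0.12 log units; within the scatter), resting on compound 1 and compound 2, whose step a 1.4-fold higher number from compound 1 to compound 2 (0.14 log units; within the scatter) is within the scatter. Compound 4 is therefore expected to give about 85000 nM in this assay, between 45000 nM and 160000 nM, with a real chance that only a limit is reported.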

Compound 4, half-maximal inhibitory concentration: 3290 nM
Compound 4: middle estimate off by 26-fold (1.41 log units), on the high side, outside the stated range (below it).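

In this assay, methyl in place of hydrogen on a saturated chain carbon bound to an oxygen next to a carbonyl group did not carry over from the core of compound 1 to the core of compound 3, giving a 20-fold lower number from compound 3 to compound 4 (1.30 log units; beyond the scatter): the same change on two cores in this assay, a 1.4-fold higher number (0.14 log units; within the scatter) from compound 1 to compound 2 and a 20-fold lower number (1.30 log units; beyond the scatter) from compound 3 to compound 4, 27-fold (1.44 log units) apart, beyond the scatter of two such steps

The benzyl for cyclohexyl change is likewise not a fixed step, giving a 30-fold lower number from compound 2 to compound 4 (1.48 log units; beyond the scatter): the same change on two cores in this assay, a 1.1-fold lower number (0.04 log units; within the scatter) from compound 1 to compound 3 and a 30-fold lower number (1.48 log units; beyond the scatter) from compound 2 to compound 4, 27-fold (1.44 log units) apart, beyond the scatter of two such steps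

The two changes therefore do not add in this set, and the lower number appears only where ethoxycarbonyl and benzyl occur together, but these four compounds do not show why this happens or whether it holds on any other core.

On these data alone, it remains open whether a longer chain in place of ethyl keeps the lower number alongside benzyl. As far as these compounds go, it is also open whether a phenethyl group or a benzyl carrying a chlorine in place of the plain benzyl would keep it alongside ethoxycarbonyl.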